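Fusing the cyclohexyl onto the thiazole of compound 3

A few compounds are considered here, and "the series" means these few. Any claim that something is new, unique, unknown or untested is made for them only; others in the source may bear on it.

Compound 1 `CC(C)c1csc(/C=C/c2cccc([C@@H](CCc3ccccc3C(C)(C)O)SCC3(CC(=O)O)CC3)c2)n1` gives 1.9 nM in an assay on membranes from lung for inhibition of cysteinyl leukotriene receptor 1 (Cavia porcellus); a lower number here means a stronger inhibitor, a higher number a weaker inhibitor.
Compound 2 `CC(C)(O)c1ccccc1CC[C@@H](SCC1(CC(=O)O)CC1)c1cccc(/C=C/c2nc(C3CC3)cs2)c1` gives 1.7 nM; 3.3 nM (2 entries) in this assay.
Compound 3 `CC(C)(O)c1ccccc1CC[C@@H](SCC1(CC(=O)O)CC1)c1cccc(/C=C/c2nc(C3CCCCC3)cs2)c1` gives 2.1 nM in this assay.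

Compound 3 holds the highest of the two single numbers in this assay, but its nearest neighbour is compound 1, which lies within the scatter of it; compound 2 has several entries rather than one number, as shown by the several entries of compound 2 in this assay, 1.7 nM; 3.3 nM (2 entries).

Compound 4 `CC(C)(O)c1ccccc1CC[C@@H](SCC1(CC(=O)O)CC1)c1cccc(/C=C/c2nc3c(s2)CCCC3)c1` has not been measured. It differs from compound 3 in that (a group of 9 heavy atoms (7 carbon, 1 nitrogen, 1 sulfur; one five-membered aromatic ring with 2 hetero atoms, one six-membered non-aromatic ring of carbon only) in place of a group of 11 heavy atoms (9 carbon, 1 nitrogen, 1 sulfur; one five-membered aromatic ring with 2 hetero atoms, one six-membered non-aromatic ring of carbon only), on a double-bonded chain carbon bound to a double-bonded chain carbon); the six-membered ring is kept but now fused to the thiazole rather than hung from it.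

Going by the values given here, one measured step bears on this region: a 1.1-fold higher number from compound 1 to compound 3 (0.04 log units; within the scatter), which was within the scatter. A change at the same place that kept potency unchanged gives no reason to expect a large shift for compound 4, though fusion is a different kind of change and widens the range.

Compound 4 is therefore estimated at 3 nM in this assay, with a range of 1 nM to 12 nM, a step of a 1.4-fold higher number from compound 3 to compound 4 (0.15 log units; within the scatter) that is expected to stay near the scatter.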

Compound 4, half-maximal inhibitory concentration: 1.5 nM
The estimate for compound 4 lay 2.0-fold (0.30 log units) above the measured number; the measured number falls inside the stated range.
By their numbers in this assay, from the lowest: compounds 4, 1 and 3 (each within the scatter of the next).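

In this assay, going by these compounds alone, the earlier compounds showed only that one group hung from the thiazole could stand in for another, whereas the fused ring shows that the six-membered ring need not hang free at all, with a 1.4-fold lower number from compound 3 to compound 4 (0.15 log units; within the scatter) for this change. The picture is the same when the fused ring replaces the smaller isopropyl-bearing group, with a 1.3-fold lower number from compound 1 to compound 4 (0.10 log units; within the scatter) despite the different ring count. Both steps are no larger than the spread of repeated entries for a single compound: the several entries of compound 2 in this assay, 1.7 nM; 3.3 nM (2 entries).

The compounds leave open whether this position accepts anything other than carbon on the added ring, such as an amine or a hydroxyl group on the fused ring. They also leave open whether a fused benzene ring would stay within the scatter.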